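The source may report more compounds than this note shows. Statements on the series, on what has been measured and on what is new or still open speak of the compounds shown alone.

Measured compounds:
compound 1, `CC(C)OC(=O)N1CCC(Oc2ncnc3c2CCN3c2ccc(C#N)cc2F)CC1`, 134% in a functional assay on CHO-K1 cells with Glucose-dependent insulinotropic receptor (Homo sapiens) as the target, read by a luciferase reporter, with a stated time of 5 h; a lower number here means a smaller maximal response, a higher number a larger maximal response
compound 2, `CC(C)OC(=O)N1CCC(Oc2ncnc3c2CCN3c2ccc(-c3cccn3C)cc2F)CC1`, 44% in this assay
compound 3, `CC(C)(C)OC(=O)N1CCC(Oc2ncnc3c2CCN3c2ccc(S(C)(=O)=O)cc2F)CC1`, 139% in this assay

Compound 3 gives the highest of the three numbers in this assay, but its nearest neighbour, compound 1, lies within the scatter of it, so the two cannot be told apart; compound 2 sits far lower. Going by the values given here, the one step that can be followed, a number 90 percentage points lower from compound 1 to compound 2 (beyond the scatter), concerns the group on the aromatic carbon at the far end of the shared core and is large.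

Compound 4, `CC(C)SC(=O)N1CCC(Oc2ncnc3c2CCN3c2ccc(S(C)(=O)=O)cc2F)CC1`, differs from compound 3 at the other end of the molecule: isopropylsulfanyl in place of tert-butoxy on a carbonyl carbon. Among the compounds with values here, no measured pair changes the group on this carbonyl carbon, so no step bears directly on it. The only related observation is that compound 1 and compound 3, which carry different groups on that carbonyl carbon as well as on the aromatic carbon, give numbers within the scatter of each other. On that slim basis the expectation for this assay is a change of a number 14 percentage points lower from compound 3 to compound 4 (beyond the scatter), that is, none beyond the scatter. Compound 4 is therefore estimated at 125%, with a range from 90% to 160%.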

Compound 4, largest response reached (reported as percent of maximum), in percent of the reference or control that the assay uses: 138%
The estimate for compound 4 lay 13 percentage points below the measured number; the measured number falls inside the stated range.
By their numbers in this assay, from the lowest: compound 2; then compounds 1, 4 and 3 (each within the scatter of the next).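

In this assay the swap of tert-butoxy for isopropylsulfanyl on the carbonyl carbon, whose other neighbour is the amide-type nitrogen in a ring, gives a number 1 percentage points lower from compound 3 to compound 4 (within the scatter) and so leaves the two compounds indistinguishable. Going by these compounds alone, this is the first direct reading at this end of the molecule: a change from five heavy atoms to four, with sulfur entering and oxygen leaving, makes no difference that the scatter allows, whereas the one step at the aromatic carbon, a number 90 percentage points lower from compound 1 to compound 2 (beyond the scatter) in the same assay, is large. Nothing measured here explains why the largest response stays within the scatter across this change.

On these data alone, one pair cannot settle how much this position accepts, so it remains open whether an amine nitrogen or a longer chain such as hexyloxy on the same carbonyl carbon would also stay within the scatter of compound 3. As far as these compounds go, it is also open whether isopropylsulfanyl would give a similar result when paired with the 1-methyl-1H-pyrrol-2-yl group of compound 2 instead of the group carried by compound 3 and compound 4.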